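From hexyl back to an aromatic ring

The source may report more compounds than this note shows. Statements on the series, on what has been measured and on what is new or still open speak of the compounds shown alone.

The values in a functional assay on MDA-MB-231 cells (Homo sapiens) for antiproliferative activity, read by sulforhodamine B assay, with a stated time of 48 h (on this read-out lower numbers stand for stronger inhibition of growth and higher numbers for weaker inhibition of growth), so far are these.
Compound 1 `O=C1COc2ccccc2N1CCCn1cc(-c2ccccc2)nn1` gives 4900 nM 
Compound 2 `CCCCCCc1cn(CCCN2C(=O)COc3ccccc32)nn1` gives 1100 nM 

Compound 2 has the lower of the two numbers. Compound 3 `O=C1COc2ccccc2N1CCCn1cc(-c2ccccn2)nn1`, not yet measured, carries pyridin-2-yl in place of hexyl on an aromatic carbon. Within the data shown here, one measured step bears on this: a 4.5-fold lower number from compound 1 to compound 2 (0.65 log units; beyond the scatter) when hexyl replaces phenyl. Pyridin-2-yl is a six-membered aromatic ring, as phenyl is, so a step of similar size towards weaker inhibition is expected in this assay here. The expected step is a 4.1-fold higher number from compound 2 to compound 3 (0.61 log units; beyond the scatter) in size. For compound 3 the estimate is 4500 nM (expected range 1800 nM to 11000 nM).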

Compound 3, concentration for 50% growth inhibition: 4800 nM
Estimate against measurement, compound 3: 1.1-fold (0.03 log units) below, within the range that was stated.
By their numbers in this assay, from the lowest: compound 2; then compounds 3 and 1 (each within the scatter of the next).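

In this assay, pyridin-2-yl and phenyl on this aromatic carbon give matching results (a 1.0-fold lower number from compound 1 to compound 3 (0.01 log units; within the scatter)), so the ring nitrogen and its hydrogen-bond acceptor make no visible difference here. Pyridin-2-yl in place of hexyl (a 4.4-fold higher number from compound 2 to compound 3 (0.64 log units; beyond the scatter)) shows that both aromatic rings stand apart from the hexyl chain, which a single ring could not show. Nothing measured here explains this gap. Still open, going by these compounds, is whether a longer chain, a shorter butyl chain or a saturated cyclohexyl ring would match hexyl. Pyridin-3-yl at this position is also untested among these compounds.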